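The compounds below may be only part of what the source reports. "The series", "measured", "known", "first", "only" and "open" are said of these compounds alone.

Among the measured compounds shown here, in an ADME assay on cells (Lymphocyte, Homo sapiens) for cytotoxicity, read by MTT assay, with a stated time of 48 h (on this read-out lower numbers stand for stronger inhibition and higher numbers for weaker inhibition), compound 1 `COC(=O)/C(=C\c1ccc(OC(=O)c2cc(OC)cc(OC)c2)cc1)Sc1ccnc2cc(Cl)ccc12` gives 84100 nM, the only number available so far. Compound 2 `COC(=O)/C(=C\c1ccc(OC(=O)c2cc(OCc3ccccc3)c(OCc3ccccc3)c(OCc3ccccc3)c2)cc1)Sc1ccnc2cc(Cl)ccc12` reads > 100000 nM, which is a limit of the assay and not a number. Compound 3 `COC(=O)/C(=C\c1ccc(OC(=O)c2ccc(OC)c(OC)c2OC)cc1)Sc1ccnc2cc(Cl)ccc12`, still unmeasured, carries 2,3,4-trimethoxyphenyl in place of 3,5-dimethoxyphenyl on a carbonyl carbon. For the measured compounds named here, the series offers no measured step between two compounds to scale this change against, so the expectation rests on compound 1 at 84100 nM alone. No shift beyond the usual scatter is expected in this assay, in either direction. The expected size of the change is a 1.0-fold higher number from compound 1 to compound 3 (0.00 log units; within the scatter). For compound 3 the estimated value is 85000 nM, with an expected range of 40000 nM to 100000 nM.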

Compound 3, half-maximal inhibitory concentration: 22400 nM
Compound 3: the middle estimate sits 3.8-fold (0.58 log units) above what was measured, outside the stated range (below it).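

In this assay the aryl group on a carbonyl carbon is shown for the first time to move the read-out: 2,3,4-trimethoxyphenyl in place of 3,5-dimethoxyphenyl gives (a 3.8-fold lower number from compound 1 to compound 3 (0.57 log units; beyond the scatter)), so this place in the series is not silent to substitution. Compound 2 gives > 100000 nM which is a limit of the assay and not a number, and steps to it cannot be read. The top of the range therefore bounds what can be compared in this series: the limit of > 100000 nM in this assay, at which 1 of the 3 values shown sits.

The step changes the count of methoxy groups and their arrangement together, and the two cannot be separated here. Open too, as far as these compounds go, is how this place would respond to a single methoxy group, a hydroxyl group, an amine or a carboxylic acid on the phenyl ring.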